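The source may hold more compounds than are shown below. What is called first, only, known or untested is meant among the compounds shown, and "the series" means these compounds.

Measured compounds:
- compound 1, `Cc1cccc(C(=O)NCN2CCC(c3nccs3)CC2)c1` — 9.8 nM
- compound 2, `Cc1cccc(NC(=O)CN2CCC(c3nccs3)CC2)c1` — 1 nM
- compound 3, `COc1cccc(C)c1NC(=O)CN1CCC(c2cccc[n+]2[O-])CC1` — 340 nM

In a functional assay on HEK293 cells for agonist activity at D(4) dopamine receptor (Homo sapiens), read by FLIPR (on this read-out higher numbers stand for an effect only at larger amounts of compound and lower numbers for an effect already at smaller amounts), compound 2 gives 1 nM, the lowest of the three numbers and thus the most potent of the set, since its gaps to both compound 1 and compound 3 lie beyond the scatter. Compound 1, a rearranged amide, gives 9.8 nM, and compound 3, which carries a different aromatic group on the saturated ring and a further substituent on the anilide, gives 340 nM.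

Compound 4, `Cc1cccc(NC(=O)CN2CCC(c3ccc(O)cc3)CC2)c1`, has not been measured. It differs from compound 2 in one place: 4-hydroxyphenyl in place of 1,3-thiazol-2-yl on a saturated ring carbon. Within the data shown here, no measured pair in this set isolates that change, so its effect is not known from the numbers at hand; the only hint is compound 3, whose different ring on the same carbon goes with 340 nM, although compound 3 also differs elsewhere. The step is expected to be upward in this assay, moderate in size: a 12-fold higher number from compound 2 to compound 4 (1.08 log units; beyond the scatter). Compound 4 is therefore estimated at 12 nM, within 2 nM to 80 nM.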

Compound 4, half-maximal effective concentration: 70 nM
Beside the measured number, compound 4's estimate is 5.8-fold (0.77 log units) below it, and the stated range covers the measured number.
By their numbers in this assay, from the lowest: compound 2; then compound 1; then compound 4; then compound 3.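

In this assay, among these compounds, putting 4-hydroxyphenyl in place of 1,3-thiazol-2-yl on the saturated ring carbon gives a 70-fold higher number from compound 2 to compound 4 (1.85 log units; beyond the scatter), and this is the first pair in the set that differs at this position alone. With the rest of the structure held constant, the group on this carbon is enough on its own to shift the number by a large step, beyond the scatter, so the position is not indifferent to which aromatic ring it carries. Nothing at hand bears on why the step is this large.

The compounds shown leave open whether the size of the step follows the change of ring or the hydroxyl group, since plain phenyl and 4-methoxyphenyl do not appear on this carbon. On these data alone, how an oxazole or a pyridine ring on the same carbon would stand against compound 2 also remains open.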